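The compounds below may be only part of what the source reports. "The series", "measured", "known", "first", "only" and "open" are said of these compounds alone.

In a functional assay on MCF7 cells (Homo sapiens) for inhibition, read by colorimetric assay and sulforhodamine B assay, with a stated time of 48 h (a higher number here means a weaker inhibitor of growth, a lower number a stronger inhibitor of growth), compound 1 (`CCCCCCCCCCCC[C@@H](O)[C@H]1CC[C@H]([C@H](O)CCCCCCCCCCNC(=O)c2cccs2)O1`) gives 2190 nM, while compound 2 (`CCCCCCCCCCCC[C@@H](O)[C@H]1CC[C@H]([C@H](O)CCCCCCCCCCNC(=O)c2ccco2)O1`) gives 100000 nM, the higher of the two numbers. Compound 3 (`CCCCCCCCCCCC[C@@H](O)[C@H]1CC[C@H]([C@H](O)CCCCCCCCCCNC(=O)c2ccoc2)O1`) has furan-3-yl in place of furan-2-yl on a carbonyl carbon. Within the data shown here, only one measured step bears on this change, a 46-fold higher number from compound 1 to compound 2 (1.66 log units; beyond the scatter), which is large but is a different swap at the same place. It shows that the group on the carbonyl carbon can matter, so a moderate move to a lower number is expected in this assay, with wide uncertainty. The expected step is a 5.0-fold lower number from compound 2 to compound 3 (0.70 log units; beyond the scatter). Compound 3 is estimated at 20000 nM, with an expected range of 3000 nM to 100000 nM.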

Compound 3, concentration for 50% growth inhibition: 26900 nM
For compound 3 the middle estimate is 1.3-fold (0.13 log units) below the measured one, within the range that was stated.
By their numbers in this assay, from the lowest: compound 1; then compound 3; then compound 2.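

In this assay the attachment point of the furan ring alone shifts the result, since furan-3-yl in place of furan-2-yl on the carbonyl carbon gives a 3.7-fold lower number from compound 2 to compound 3 (0.57 log units; beyond the scatter) with the same atoms. This modest gain still leaves the thiophen-2-yl amide ahead, as a 12-fold higher number from compound 1 to compound 3 (1.09 log units; beyond the scatter) shows for the furan-3-yl change. No measurement here explains why either swap matters.

From the compounds shown here alone, whether thiophen-3-yl would differ from thiophen-2-yl as furan-3-yl differs from furan-2-yl remains open. So does where a phenyl group on the carbonyl carbon would fall relative to compound 1.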